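Trimming a Benzyl to a Phenyl on a Weak Series

The compounds below may be only part of what the source reports. "The series", "measured", "known", "first", "only" and "open" are said of these compounds alone.

Compound 1 `O/N=C(/Nc1cccc(F)c1)c1ccc2occc2c1`: 32700 nM
Compound 2 `O/N=C(/Nc1cccc(Cc2ccccc2)c1)c1ccc2occc2c1`: a limit, > 30000 nM

In an assay on isolated protein for inhibition of Indoleamine 2,3-dioxygenase 1 (Homo sapiens), read by spectrophotometry (on this read-out higher numbers stand for weaker inhibition and lower numbers for stronger inhibition), compound 1 gives 32700 nM. Compound 2 reaches only the limit of > 30000 nM, so its own number is not known. The step that the limit leaves unreadable from compound 1 to compound 2 therefore cannot be sized, a consequence of the limit of > 30000 nM in this assay, at which 1 of the 2 values shown sits. Compound 3 `O/N=C(/Nc1cccc(-c2ccccc2)c1)c1ccc2occc2c1` differs from compound 2 by phenyl in place of benzyl on an aromatic carbon. Among the compounds with values here, no measured step bears directly on this change, and the one neighbouring step is unreadable. Compound 3 is therefore expected to remain in the same weak region, the step that the limit leaves unreadable from compound 2 to compound 3 being expected to stay within the scatter. Compound 3 is estimated at 35000 nM, within 10000 nM to 100000 nM.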

Compound 3, half-maximal inhibitory concentration: 11000 nM
Beside the measured number, compound 3's estimate is 3.2-fold (0.50 log units) above it; the measured number falls inside the stated range.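

In this assay, this aromatic carbon, meta to a large group, now shows changes beyond the scatter: phenyl in place of benzyl gives an at least 2.7-fold lower number from compound 2 to compound 3 (0.43 log units; beyond the scatter), and phenyl in place of fluoro gives a 3.0-fold lower number from compound 1 to compound 3 (0.47 log units; beyond the scatter). Compound 2 stands at a limit, so the first of these steps gives only a minimum size: the limit of > 30000 nM in this assay, at which 1 of the 3 values shown sits.

As far as these compounds go, it remains open whether a pyridine ring, a methoxy group or an amine on this aromatic carbon would keep the lower number, and whether a substituent on the phenyl ring of compound 3 would shift it further.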